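A few compounds are considered here, and "the series" means these few. Any claim that something is new, unique, unknown or untested is made for them only; others in the source may bear on it.

Measured in a functional assay on HeLa cells (Homo sapiens) for antiproliferative activity, read by sulforhodamine B assay, with a stated time of 48 h; a higher number here means a weaker inhibitor, a lower number a stronger inhibitor:
- Compound 1 `COc1ccc2nc(-c3ccc(N/C=C\C(=O)c4ccc(OC)c(O)c4)c(C)c3)sc2c1`: 12000 nM
- Compound 2 `COc1ccc2nc(-c3ccc(N/C=C\C(=O)c4ccc(OC)c(F)c4)c(C)c3)sc2c1`: 600 nM
- Compound 3 `COc1ccc2nc(-c3ccc(N/C=C\C(=O)c4ccc(OC)c([N+](=O)[O-])c4)cc3)sc2c1`: 17600 nM

In this assay, compound 3 at 17600 nM lies within the scatter of compound 1 at 12000 nM, while compound 2 at 600 nM has a lower number, beyond the scatter.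

Compound 4 `COc1ccc2nc(-c3ccc(N/C=C\C(=O)c4ccc(OC)c([N+](=O)[O-])c4)c(C)c3)sc2c1` follows from compound 3 by one change, methyl in place of hydrogen on an aromatic carbon.

Among the measured compounds shown here, no measured step isolates this change. For the measured compounds named here, the only step available is a 20-fold lower number from compound 1 to compound 2 (1.30 log units; beyond the scatter), a large one, but it is fluoro in place of hydroxy on an aromatic carbon, elsewhere in the structure. It shows that a single change can move the number widely in this series, which argues for a broad range, but it gives no direction for the methyl. No shift beyond the scatter is therefore expected in this assay. The expected step is a 1.5-fold lower number from compound 3 to compound 4 (0.17 log units; within the scatter). For compound 4 the estimated value is 12000 nM, with an expected range of 3000 nM to 40000 nM.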

Compound 4, half-maximal inhibitory concentration: 17600 nM
Beside the measured number, compound 4's estimate is 1.5-fold (0.17 log units) below it; the measured number falls inside the stated range.
By their numbers in this assay, from the lowest: compound 2; then compounds 1, 3 and 4 (each within the scatter of the next).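

In this assay, methyl in place of hydrogen on an aromatic carbon, ortho to a large group and meta to a 6-methoxy-1,3-benzothiazol-2-yl group, gives no change at the digits printed from compound 3 to compound 4 (within the scatter), so with nitro kept in the series this position tolerates the added methyl without a readable shift. With that methyl present, the other site of change carries the large effect: a 29-fold higher number from compound 2 to compound 4 (1.47 log units; beyond the scatter) is the step for nitro in place of fluoro, whereas a 1.5-fold higher number from compound 1 to compound 4 (0.17 log units; within the scatter), for nitro in place of hydroxy, leaves those two groups unseparated. The data offer no explanation for either outcome.

As far as these compounds go, whether the methyl step stays this small when fluoro replaces nitro remains open. Also open, from the compounds shown here alone, is how an ethyl group at the methyl position, or an amine at the nitro position, would read in this assay.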